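Swapping the aryl group on a thiazolidinone core: cytotoxicity

This account rests on a few compounds, and the source may have more. Where it says the series, first, only, none or still open, it means among the compounds named here.

Compound 1, `O=C1CSC(c2cccc(O)c2)N1CCN1CCCCC1`: 100%
Compound 2, `COc1ccccc1C1SCC(=O)N1CCN1CCCCC1`: 100%
Compound 3, `O=C1CSC(c2ccccc2[N+](=O)[O-])N1CCN1CCCCC1`: 100%

In an ADME assay on Vero cells (Chlorocebus sabaeus) for cytotoxicity, read by neutral red uptake, tested at 98 ug/mL (a higher number here means a weaker effect of the compound at the concentration tested, a lower number a stronger effect), compound 1 stands level with compounds 2 and 3; its nearest neighbour is compound 2 and its furthest is compound 3, both without change within the scatter. The step from compound 1 to compound 4, `Cc1ccc(C2SCC(=O)N2CCN2CCCCC2)cc1`, is 4-methylphenyl in place of 3-hydroxyphenyl on a saturated ring carbon. For the measured compounds named here, the only measured step of a single change, no change at the digits printed from compound 2 to compound 3 (within the scatter), was flat. Going by the values given here, no measured step touches the 4-methylphenyl group, so the expectation rests on the flatness of the whole set, and the step from compound 1 is expected to be no change at the digits printed from compound 1 to compound 4 (within the scatter), with nothing beyond the scatter in this assay. Compound 4 is accordingly estimated at 100%, in the range 88% to 100%.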

Compound 4, a percentage reported as activity, at one concentration (the size of the read-out at that concentration, not a potency): 100%
Compound 4: the middle estimate sits on the measured number at the digits printed; the range from low to high includes it.
By their numbers in this assay, from the lowest: compounds 1, 2, 3 and 4 (each within the scatter of the next).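

In this assay, putting 4-methylphenyl in place of 3-hydroxyphenyl on the saturated ring carbon gives no change at the digits printed from compound 1 to compound 4 (within the scatter) even though the entering group has no hydrogen-bond donor or acceptor. The earlier step exchanged methoxy for nitro on the aromatic ring, whereas this one shows that the read-out also holds when the whole aryl group and its hydroxyl are replaced. Nothing available explains this result. Still open, as far as these compounds go, is whether an amine or a carboxylic acid on the phenyl ring, or a longer chain there, would leave the read-out equally flat.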